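Working notes: from compound 2 to compound 3

This account rests on a few compounds, and the source may have more. Where it says the series, first, only, none or still open, it means among the compounds named here.

compound 1 `C=CC(=O)Nc1ccc(Cl)c(S(=O)(=O)N(C)C)c1` gives 24600 nM
compound 2 `C=CS(=O)(=O)Nc1ccc(Cl)c(S(=O)(=O)N(C)C)c1` gives 9900 nM

In a functional assay on HCT-116 cells (Homo sapiens) for antiproliferative activity, read by MTT assay, with a stated time of 72 h (on this read-out higher numbers stand for weaker inhibition and lower numbers for stronger inhibition), compound 2 holds the lower of the two numbers, at 9900 nM, and compound 1 is the nearest and only comparison. Within the data shown here, the next entry is compound 3 `COC(=O)/C=C/CNc1ccc(Cl)c(S(=O)(=O)N(C)C)c1`, which has no measurement yet. Its structural change is 3-(methoxycarbonyl)prop-2-en-1-yl in place of vinylsulfonyl on a nitrogen on an aromatic ring.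

Among the measured compounds shown here, only one measured step bears on this change: a 2.5-fold lower number from compound 1 to compound 2 (0.40 log units; beyond the scatter). It was modest, though beyond the scatter, and it was made at the same place on the shared core. It exchanged vinylcarbonyl for vinylsulfonyl, however, and the group entering now is neither of these, so it offers only a loose guide to size and none to direction. A small move towards a higher number in this assay is expected, not clearly beyond the scatter, with wide uncertainty on both sides.

The expected step is a 1.4-fold higher number from compound 2 to compound 3 (0.15 log units; within the scatter).

For compound 3 the estimated value is 14000 nM, with an expected range of 4500 nM to 40000 nM.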

Compound 3, half-maximal inhibitory concentration: > 30000 nM
Compound 3 ended at the assay's limit (the forecaster's own chance of this, stated with the estimate: 10%); middle value at least 2.1-fold (0.33 log units) from the limit.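

In this assay compound 3 stands only as a limit of the assay, not as a number: the limit of > 30000 nM in this assay, at which 1 of the 3 values shown sits.

Even so, the change on the nitrogen on an aromatic ring can be read against compound 2: 3-(methoxycarbonyl)prop-2-en-1-yl in place of vinylsulfonyl gives an at least 3.0-fold higher number from compound 2 to compound 3 (0.48 log units; beyond the scatter), so this position tolerates less than the earlier exchange of vinylcarbonyl for vinylsulfonyl could show, and the first move towards weaker inhibition from compound 2 appears here. Against the vinylcarbonyl group, the same entering group gives an at least 1.2-fold higher number from compound 1 to compound 3 (0.08 log units; that floor lies within the scatter), so compound 1 and compound 3 cannot be put in order, and the series shows only that compound 2 keeps the lowest number of the three.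

Going by these compounds, how far compound 3 actually lies from the limit stays open, as does whether the step belongs to the methyl ester, to the chain carrying it or to the loss of the vinylsulfonyl group itself. Also open, on these data alone, is how a carboxylic acid, a primary amide or a longer chain on this nitrogen would read in this assay, and whether the order seen here would hold with other groups elsewhere on the shared core.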